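A few compounds are considered here, and "the series" means these few. Any claim that something is new, unique, unknown or untested is made for them only; others in the source may bear on it.

Two compounds have been measured in a functional assay on U-251 cells (Homo sapiens) for antiproliferative activity; on this read-out higher numbers stand for weaker inhibition of growth and lower numbers for stronger inhibition of growth:

Compound 1, `Cc1ccnc2nc(-c3ccc4ccccc4c3)cc(O)c12`, gives 646 nM.
Compound 2, `Cc1ccc2c(O)cc(-c3ccc4ccccc4c3)nc2n1`, gives 4570 nM.

On the numbers shown, compound 2 stands with the highest number of the two; compound 1 is its only neighbour and carries the lower number, and the gap between them lies beyond the usual scatter. Compound 3, `Cc1cc(C)c2c(O)cc(-c3ccc4ccccc4c3)nc2n1`, has not yet been measured in this assay. It differs from compound 2 by methyl in place of hydrogen on an aromatic carbon. Within the data shown here, no measured pair of compounds shows what such a methyl does here, so the size of this step cannot be read from the data. The step of a 1.5-fold lower number from compound 2 to compound 3 (0.18 log units; within the scatter) is expected to be small, possibly toward a lower number but quite likely within the scatter. Compound 3 is therefore estimated at 3000 nM, with a range from 800 nM to 12000 nM.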

Compound 3, concentration for 50% growth inhibition: 15800 nM
For compound 3 the middle estimate is 5.3-fold (0.72 log units) below the measured one; measured number above the stated range.
By their numbers in this assay, from the lowest: compound 1; then compound 2; then compound 3.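

In this assay, methyl in place of hydrogen on the aromatic carbon opposite the ring nitrogen gives a 3.5-fold higher number from compound 2 to compound 3 (0.54 log units; beyond the scatter), so this position does not tolerate the change without loss: the added methyl goes with weaker inhibition of growth, not the small shift a lack of data left possible. The same change at a different aromatic carbon gives a 24-fold higher number from compound 1 to compound 3 (1.39 log units; beyond the scatter), which also points toward weaker inhibition of growth, so in these compounds both single methyl steps leading to the compound with two methyl groups run the same way. Nothing measured here bears on the cause of these steps.

Going by these compounds, it remains open whether the loss is particular to methyl or would also follow from a chlorine atom, a methoxy group, an amine or an ethyl chain on the same carbon. On these data alone, it also remains open whether these steps would hold on a core with a different aryl group in place of the one shared here.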